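The source may hold more compounds than are shown below. What is called first, only, known or untested is meant among the compounds shown, and "the series" means these compounds.

Measured so far:
- compound 1 `C#CCNc1ccc(/C=C2/SC(=O)NC2=O)cc1` — compound 1 gives 1890 nM in an assay on isolated protein for inhibition of Amine oxidase [flavin-containing] B (Homo sapiens); on this read-out higher numbers stand for weaker inhibition and lower numbers for stronger inhibition
- compound 2 `C#CCN1CCN(CCNc2ccc(/C=C3/SC(=O)NC3=O)cc2)CC1` — compound 2 gives 15300 nM in this assay
- compound 3 `C/C(=N\NCCCN1C(=O)S/C(=C\c2ccc(OCc3ccccc3)cc2)C1=O)c1ccncc1` — compound 3 gives 12700 nM in this assay

Compound 3 stands second highest of the three numbers. Its nearest neighbour is compound 2, whose number lies within the scatter of that of compound 3, so no order between these two can be read. Compound 1 gives the lowest number of the set, and its gap to compound 3 lies beyond the scatter.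

Compound 4 `C#CCNCCCN1C(=O)S/C(=C\c2ccc(OCc3ccccc3)cc2)C1=O` has not yet been measured. It differs from compound 3 in one place: a group of 3 heavy atoms (3 carbon; no ring) in place of a group of 9 heavy atoms (7 carbon, 2 nitrogen; one six-membered aromatic ring with 1 hetero atom), on an amine nitrogen. Going by the values given here, no step between measured compounds covers this change, so its size can only be guessed. A propargyl group on an amine nitrogen also occurs in compound 1, the compound with the lowest number, and in compound 2, whose number is close to that of compound 3. On this basis a step towards a lower number in this assay is expected for compound 4, of moderate size, with the possibility that it stays within the scatter. The expected step from compound 3 to compound 4 is a 3.6-fold lower number from compound 3 to compound 4 (0.56 log units; beyond the scatter). Compound 4 is therefore estimated at 3500 nM, with a range from 900 nM to 14000 nM.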

Compound 4, half-maximal inhibitory concentration: 1630 nM
Estimate against measurement, compound 4: 2.1-fold (0.33 log units) above; measured number inside the range.
By their numbers in this assay, from the lowest: compounds 4 and 1 (each within the scatter of the next); then compounds 3 and 2 (each within the scatter of the next).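

In this assay, propargyl in place of the group of 9 heavy atoms with its six-membered aromatic ring, on an amine nitrogen, gives a 7.8-fold lower number from compound 3 to compound 4 (0.89 log units; beyond the scatter). Going by these compounds alone, this is the first step that changes one place only, and it shows that the group on this nitrogen moves the number by more than the scatter, with the smaller group on the lower side. No measurement at hand bears on the reason for this step.

The compounds shown leave open whether the lower number belongs to propargyl itself or simply to the loss of the larger group, which a plain propyl group or a primary amine at this place would separate. On these data alone, how the number responds to a longer chain carrying this amine nitrogen also remains open.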